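Nitro for Trifluoromethoxy on the Thiourea of Compound 1

The source may hold more compounds than are shown below. What is called first, only, known or untested is meant among the compounds shown, and "the series" means these compounds.

Measured so far:
compound 1, `CC1(C)CCOc2ccc(NC(=S)Nc3ccc(OC(F)(F)F)cc3)cc21`: 4300 nM
compound 2, `CCC1(CC)CC(CC)(CC)c2cc(NC(=O)Nc3ccc(OC(F)(F)F)cc3)ccc2O1`: 3000 nM
compound 3, `CCC1(CC)CC(C)(C)Oc2ccc(NC(=O)Nc3ccc([N+](=O)[O-])cc3)cc21`: 2050 nM

In a functional assay on A2780 cells (Homo sapiens) for inhibition, with a stated time of 72 h (a lower number here means a stronger inhibitor, a higher number a weaker inhibitor), compound 1 has the highest of the three numbers. Compound 2 gives 3000 nM, which lies within the scatter of compound 1; compound 3 gives 2050 nM, which lies beyond it. Compound 4, `CC1(C)CCOc2ccc(NC(=S)Nc3ccc([N+](=O)[O-])cc3)cc21`, differs from compound 1 in one place: nitro in place of trifluoromethoxy on an aromatic carbon. Within the data shown here, no measured pair isolates this change; compound 3 carries a nitro group but differs from compound 1 elsewhere as well. The step from compound 1 to compound 4 is therefore expected to be small, toward a lower number, and possibly not beyond the scatter, a 1.7-fold lower number from compound 1 to compound 4 (0.24 log units; within the scatter). Compound 4 is estimated at 2500 nM, with a range of 1000 nM to 6000 nM.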

Compound 4, half-maximal inhibitory concentration: 6400 nM
Compound 4: middle estimate off by 2.6-fold (0.41 log units), on the low side; measured number above the stated range.
By their numbers in this assay, from the lowest: compounds 3, 2, 1 and 4 (each within the scatter of the next, the first and the last beyond it).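

Among these compounds, compound 1 to compound 4 is the first pair to isolate this replacement: nitro in place of trifluoromethoxy on an aromatic carbon, para to a large group, gives a 1.5-fold higher number from compound 1 to compound 4 (0.17 log units; within the scatter) in this assay. On the core of compound 1, these two groups therefore cannot be told apart in this assay. No measured property bears on this step.

On these data alone, it remains open whether an amine or a carboxylic acid at this position would give a step beyond the scatter. As far as these compounds go, whether the same replacement reads alike on the core of compound 3 is also open.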